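The source may hold more compounds than are shown below. What is called first, only, known or untested is meant among the compounds shown, and "the series" means these compounds.

Of the compounds shown here, three have so far been tested in a functional assay on NCI-H460 cells (Homo sapiens) for cytotoxicity, read by sulforhodamine B assay, with a stated time of 48 h, tested at 0.001 uM; a lower number here means a stronger effect, a higher number a weaker effect of the compound at the concentration tested. Compound 1 `COc1cc(C)cc(-c2nn(CC#N)cc2-c2ccc(-c3cccc(C(C)=O)c3)nc2)c1` gives 104%, compound 2 `Cc1cc(O)cc(-c2nn(CC#N)cc2-c2ccnc(-c3ccc(Oc4ccccc4)cc3)c2)c1` gives 100%, and compound 3 `COc1cc(C)cc(-c2nn(CC#N)cc2-c2ccnc(-c3ccc(N(C)C)cc3)c2)c1` gives 103%. These three numbers all lie within the usual scatter of one another, so compound 3 cannot be told apart from compound 1 or compound 2 on these data. Compound 4 `Cc1cc(O)cc(-c2nn(CC#N)cc2-c2ccnc(-c3ccc(N(C)C)cc3)c2)c1` has not yet been measured. It differs from compound 3 in one place: hydrogen in place of methyl on an oxygen on an aromatic ring. Because hydroxy-bearing compound 2 gives 100% in this assay, no step beyond the scatter is expected from this change. Compound 4 is therefore expected to give about 101%, in a range from 92% to 110%. The estimated step of a number 2 percentage points lower from compound 3 to compound 4 (within the scatter) is expected to stay within the scatter.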

Compound 4, a percentage reported as activity, at one concentration (the size of the read-out at that concentration, not a potency): 109%
For compound 4 the middle estimate is 8 percentage points below the measured one; the measured number falls inside the stated range.
By their numbers in this assay, from the lowest: compounds 2, 3, 1 and 4 (each within the scatter of the next).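

In this assay, methoxy to hydroxy on this aromatic ring gives a number 6 percentage points higher from compound 3 to compound 4 (within the scatter), so removing the methyl from this oxygen has no readable effect at the single concentration tested. Dimethylamino in place of phenoxy gives a number 9 percentage points higher from compound 2 to compound 4 (within the scatter), so this second change, with the hydroxy group kept, shows no readable effect either. Nothing available explains these results.

Going by these compounds, whether a longer chain on this oxygen, such as ethoxy, or an amine in place of the hydroxy would also leave the number unchanged stays open. On these data alone, whether these compounds would differ at higher concentrations also stays open.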